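Losing the fluoro group at the limit

The source may report more compounds than this note shows. Statements on the series, on what has been measured and on what is new or still open speak of the compounds shown alone.

In a functional assay on LN-229 cells (Homo sapiens) for antiproliferative activity, with a stated time of 72 h (on this read-out lower numbers stand for stronger inhibition and higher numbers for weaker inhibition), compound 2 `Nc1ncnn2c([C@@H]3O[C@H](CO)[C@@H](O)[C@H]3O)cc(C#Cc3ccc(F)cc3)c12` gives > 100000 nM as a limit. Compound 3 `Nc1ncnn2c([C@@H]3O[C@H](CO)[C@@H](O)[C@H]3O)cc(C#Cc3cccs3)c12` gives > 100000 nM as a limit too. Compound 2 thus stands at the limit of > 100000 nM in this assay, at which 2 of the 3 values shown sit, in this read-out. Among the compounds with values here, compound 1 `CCCC#Cc1cc([C@@H]2O[C@H](CO)[C@@H](O)[C@H]2O)n2ncnc(N)c12` gives 40 nM in this assay as the only exact number. Compound 4 `Nc1ncnn2c([C@@H]3O[C@H](CO)[C@@H](O)[C@H]3O)cc(C#Cc3ccccc3)c12` differs from compound 2 by hydrogen in place of fluoro on an aromatic carbon with hydrogen in place of fluoro on an aromatic carbon. Within the data shown here, no measured step makes this exact change, so two large steps bear on it only indirectly, an at least 2500-fold higher number from compound 1 to compound 2 (3.39 log units; beyond the scatter) and an at least 2500-fold higher number from compound 1 to compound 3 (3.39 log units; beyond the scatter) on replacing propyl with a ring group. Compound 4 keeps a ring group there, as phenyl. The expected result is a number no higher from compound 2 to compound 4 (the limit leaves the size open) and so no step beyond the scatter. For compound 4 the estimate is 100000 nM with an expected range from 25000 nM to 200000 nM in this read-out.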

Compound 4, half-maximal inhibitory concentration: 88000 nM
Compound 4: middle estimate off by 1.1-fold (0.06 log units), on the high side; low and high end bracket the measured number.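

In this assay, the ring group itself now carries the loss, with no fluoro group needed: phenyl in place of propyl gives a 2200-fold higher number from compound 1 to compound 4 (3.34 log units; beyond the scatter). Hydrogen in place of fluoro gives an at least 1.1-fold lower number from compound 2 to compound 4 (0.05 log units; that floor lies within the scatter), and phenyl in place of thiophen-2-yl gives an at least 1.1-fold lower number from compound 3 to compound 4 (0.05 log units; that floor lies within the scatter), so neither change shows a step beyond the scatter. Compound 2 remains a limit and not a number: the limit of > 100000 nM in this assay, at which 2 of the 4 values shown sit.

The compounds shown leave open how far the true sizes of those two steps reach. They also leave open whether a longer chain than propyl, or an amine at the end of the chain, would stay near compound 1.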